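This account rests on a few compounds, and the source may have more. Where it says the series, first, only, none or still open, it means among the compounds named here.

Measured compounds in an ADME assay on MCF7 cells (Homo sapiens) for cytotoxicity, read by MTT assay, with a stated time of 48 h; on this read-out higher numbers stand for weaker inhibition and lower numbers for stronger inhibition:

- compound 1 `C=C1[C@H](OC(C)=O)[C@H]2[C@@H](OC(=O)c3ccccc3)[C@@H](C)C[C@]2(OC(C)=O)C(=O)[C@@H](C)/C=C/C(C)(C)C(=O)[C@H](OC(C)=O)[C@H]1OC(C)=O`: > 100000 nM, a limit of the assay, not a number
- compound 2 `C=C1[C@H](OC(C)=O)[C@H]2[C@@H](OC(=O)c3ccccc3)[C@@H](C)C[C@]2(OC(C)=O)C(=O)[C@@H](C)/C=C/C(C)(C)C(=O)[C@H](O)[C@H]1OC(C)=O`: > 100000 nM, also a limit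
- compound 3 `C=C1[C@H](OC(C)=O)[C@H]2[C@@H](OC(=O)c3ccccc3)[C@](C)(O)C[C@]2(O)C(=O)[C@@H](C)/C=C/C(C)(C)C(=O)[C@H](OC(=O)C(C)C)[C@H]1OC(C)=O`: > 100000 nM, also a limit

In this series all three measured values sit at the limit of > 100000 nM in this assay, at which 3 of the 3 values shown sit, so no ordering among them is readable. Compound 1 and compound 2 differ by acetyl in place of hydrogen on an oxygen on a saturated carbon; the step that the two limits leave unreadable from compound 2 to compound 1 cannot be sized, as both values are limits. The difference between the core of compound 3 and the core of compound 2 is not broken down here.

Compound 4 `C=C1[C@H](OC(C)=O)[C@H]2[C@@H](OC(=O)c3ccccc3)[C@](C)(OC(C)=O)C[C@]2(O)C(=O)[C@@H](C)/C=C/C(C)(C)C(=O)[C@H](OC(=O)C(C)C)[C@H]1OC(C)=O` is not yet measured. It differs from compound 3 by acetyl in place of hydrogen on an oxygen on a saturated carbon, the same change as that from compound 2 to compound 1, at a place described in the same words. The step that the limit leaves unreadable from compound 3 to compound 4 is expected to be small, because compound 3 gives > 100000 nM and the matching change between compound 2 and compound 1 left both values at the limit. Compound 4 is therefore estimated at 150000 nM, with a range from 40000 nM to 1000000 nM, most probably reported again only as a limit.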

Compound 4, half-maximal inhibitory concentration: 50200 nM
For compound 4 the middle estimate is 3.0-fold (0.48 log units) above the measured one; the measured number falls inside the stated range.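

In this assay, acetyl in place of hydrogen on an oxygen on a saturated carbon gives an at least 1.9-fold lower number from compound 3 to compound 4 (0.29 log units; that floor lies within the scatter). The matching step from compound 2 to compound 1 cannot be read, and both of its values are limits of the assay: the limit of > 100000 nM in this assay, at which 3 of the 4 values shown sit.

This shows the change on one core only, with a floor that stays within the scatter; it does not show that the step carries from one core to another, or how large it is on either core.

Open, from the compounds shown here alone, is what a longer acyl chain, an amine or a carboxylic acid in place of the acetyl would give in this assay. Also open, going by these compounds, is whether the same change on the core of compound 2 would give any readable number.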